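This account rests on a few compounds, and the source may have more. Where it says the series, first, only, none or still open, it means among the compounds named here.

Of the compounds shown here, two have been measured in a functional assay on Hep 3B2 cells (Homo sapiens) for antiproliferative activity, read by MTT assay, with a stated time of 24 h, tested at 0.05 ug/mL; a higher number here means a stronger effect of the compound at the concentration tested, a lower number a weaker effect. Compound 1 `CCOc1ccc2nc(C(=O)Nc3c(F)cc(-c4cccc(F)c4)cc3F)c(C)c(C(=O)O)c2c1` gives 0.98% there, and compound 2 `COc1ccc2nc(C(=O)Nc3c(F)cc(-c4cccc(F)c4)cc3F)c(C)c(C(=O)O)c2c1` gives -0.66%. Within the data shown here, compound 2 holds the lower of the two numbers, but the single measured step, a number 1.6 percentage points lower from compound 1 to compound 2 (within the scatter), is within the scatter, so the two compounds cannot be told apart on this assay. Compound 3 `Cc1c(C(=O)Nc2c(F)cc(-c3cccc(F)c3)cc2F)nc2ccc(C(F)(F)F)cc2c1C(=O)O` is the next compound to be measured. Relative to compound 2 it carries trifluoromethyl in place of methoxy on an aromatic carbon. Among the measured compounds shown here, no measured step changes the group on the aromatic carbon; the only step on record, a number 1.6 percentage points lower from compound 1 to compound 2 (within the scatter), concerns the saturated chain carbon bound to an oxygen on the aromatic ring and was within the scatter. There is thus no basis for expecting a step beyond the scatter in this assay. For compound 3 the expected value is 2%, with a range from -8% to 14%. The expected step is a number 2.7 percentage points higher from compound 2 to compound 3 (within the scatter).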

Compound 3, a percentage reported as inhibition, at one concentration (the size of the read-out at that concentration, not a potency): 1.68%
Compound 3: the middle estimate sits 0.3 percentage points above what was measured; the range from low to high includes it.
By their numbers in this assay, from the lowest: compounds 2, 1 and 3 (each within the scatter of the next).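

In this assay, trifluoromethyl in place of methoxy on the aromatic carbon gives a number 2.3 percentage points higher from compound 2 to compound 3 (within the scatter), and trifluoromethyl in place of ethoxy gives a number 0.7 percentage points higher from compound 1 to compound 3 (within the scatter). The earlier step varied only the chain on the oxygen; these two replace the whole ether group with a group holding no oxygen, and the hydrogen-bond acceptor of methoxy is lost, yet the three compounds cannot be told apart in this assay. No available evidence bears on this result.

As far as these compounds go, whether an amine, a hydroxyl group or a longer chain at this aromatic carbon would give a step beyond the scatter remains open. With only one concentration shown, the readings tell only the size of the effect at that concentration, and no stronger or weaker effect can be told among these compounds there.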